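The source may hold more compounds than are shown below. What is called first, only, known or untested is meant among the compounds shown, and "the series" means these compounds.

Measured compounds:
- Compound 1, `CNC(=O)c1cc(C(=O)NC2CCC2)cn(Cc2cccc(NC)c2)c1=O`: 3.6
- Compound 2, `CNC(=O)c1cc(C(=O)NC2CCC2)cn(Cc2ccccc2)c1=O`: 3.8
- Compound 3, `CNC(=O)c1cc(C(=O)NC2CCC2)cn(Cc2cccnc2)c1=O`: 1.8

In a physicochemical assay for lipophilicity, at pH 7.4 (a lower number here means a more polar compound, a higher number a more lipophilic compound), compound 2 gives the highest of the three numbers. Its nearest neighbour is compound 1, and the step of a number 0.20 log units higher from compound 1 to compound 2 (within the scatter) lies within the scatter, so the two cannot be told apart. Compound 3 stands far off: the step of a number 2.00 log units lower from compound 2 to compound 3 (beyond the scatter) is large.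

Compound 4, `CNC(=O)c1cc(C(N)=O)cn(Cc2ccccc2)c1=O`, has not yet been measured. It differs from compound 2 in one place:

hydrogen in place of cyclobutyl on an amide-type nitrogen

None of the three measured steps touches this part of the molecule. The steps of a number 0.20 log units higher from compound 1 to compound 2 (within the scatter) and a number 2.00 log units lower from compound 2 to compound 3 (beyond the scatter), and likewise a number 1.80 log units lower from compound 1 to compound 3 (beyond the scatter), all change the aromatic ring on the saturated chain carbon, while the amide nitrogen carrying the cyclobutyl group stays the same throughout. The measured data therefore give no direct guide to the size of this step. Going only by the counted difference, with four carbon atoms leaving and a single hydrogen entering, a lower number is expected in this assay for compound 4, clearly beyond the scatter, estimated as a number 1.50 log units lower from compound 2 to compound 4 (beyond the scatter). Compound 4 is thus expected to give about 2.3, within a range from 1.7 to 2.9.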

Compound 4, distribution coefficient: 2
Compound 4: middle estimate off by 0.30 log units, on the high side, and the stated range covers the measured number.
By their numbers in this assay, from the lowest: compounds 3 and 4 (each within the scatter of the next); then compounds 1 and 2 (each within the scatter of the next).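

Until now every change sat on the aromatic ring, and the amide nitrogen carrying the cyclobutyl group stayed the same, so nothing showed whether this part of the molecule counts in this assay. Replacing cyclobutyl with hydrogen on this amide-type nitrogen, which turns cyclobutylcarbamoyl into carbamoyl, gives a number 1.80 log units lower from compound 2 to compound 4 (beyond the scatter) and so shows that it does count. This step is large and comparable in size to a number 2.00 log units lower from compound 2 to compound 3 (beyond the scatter), which means that a change at this nitrogen and the swap of phenyl for pyridin-3-yl each move the number by a similar amount, and no measurement shown here accounts for the size of the new step.

Going by these compounds, with only cyclobutyl and hydrogen on this nitrogen, the path between the two values is unknown, and a methyl group, a straight butyl chain or a chain ending in an amine or a carboxylic acid could each show whether the number follows the carbon count or depends on the shape and nature of the group. Also open, on these data alone, is how the step at this nitrogen would combine with the ring change in a single compound carrying both carbamoyl and pyridin-3-yl.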